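A few compounds are considered here, and "the series" means these few. Any claim that something is new, unique, unknown or untested is made for them only; others in the source may bear on it.

Measured in a functional assay on MCF7 cells (Homo sapiens) for antiproliferative activity, read by MTT assay, with a stated time of 48 h; a higher number here means a weaker inhibitor, a lower number a stronger inhibitor:
- compound 1 `COc1cc(-c2nnc3c(OC)cc(-c4ccc5[nH]ccc5c4)cn23)cc(OC)c1OC`: 80 nM
- compound 2 `COc1cc(-c2nnc3c(OCC(F)(F)F)cc(-c4ccc5[nH]ccc5c4)cn23)cc(OC)c1OC`: 608 nM

Of these two numbers, compound 1 has the lower, so it is the stronger inhibitor in this assay. For the measured compounds named here, its only measured neighbour differs by a 7.6-fold higher number from compound 1 to compound 2 (0.88 log units; beyond the scatter). That change puts trifluoromethyl in place of hydrogen on a saturated chain carbon bound to an oxygen on an aromatic ring.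

Compound 3 `COc1cc(-c2nnc3c(OC)cc(-c4ccc5[nH]cc(C=O)c5c4)cn23)cc(OC)c1OC` keeps the core of compound 1 and changes a different place: formyl in place of hydrogen on an aromatic carbon. Put simply, this is formyl in place of hydrogen on an aromatic carbon, turning 1H-indol-5-yl into 3-formyl-1H-indol-5-yl.

Going by the values given here, no measured step tests this change directly. Among the compounds with values here, the one available step, a 7.6-fold higher number from compound 1 to compound 2 (0.88 log units; beyond the scatter), is only a loose guide: it shows that a single added group can move the number beyond the scatter, here upward. A modest rise is therefore expected, though with wide uncertainty. The expected size is a 3.1-fold higher number from compound 1 to compound 3 (0.49 log units; beyond the scatter). For compound 3 the estimated value is 250 nM. The expected range runs from 60 nM to 1000 nM.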

Compound 3, half-maximal inhibitory concentration: > 10000 nM
Compound 3 was reported as a limit (the forecaster's own chance of this, stated with the estimate: 3%); at least 40-fold (1.60 log units) between middle value and limit.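

The earlier pair changed only the chain on an oxygen, whereas compound 3 is the first change shown on the 1H-indol-5-yl group, and in this assay formyl in place of hydrogen there brings an at least 120-fold higher number from compound 1 to compound 3 (2.09 log units; beyond the scatter). Compound 3 is reported only as a limit, not as a number, so the full size of this step stays unknown: the limit of > 10000 nM in this assay, at which 1 of the 3 values shown sits.

Formyl adds only 2 heavy atoms, yet at this aromatic carbon, two ring bonds from the ring nitrogen, it moves the number further than the trifluoromethyl change at the other place, which gave a 7.6-fold higher number from compound 1 to compound 2 (0.88 log units; beyond the scatter).

With a single group at this carbon, the compounds shown cannot say whether the loss belongs to formyl itself or would follow any addition at this place. A methyl, a hydroxymethyl, a nitrile, an amine or a carboxylic acid on the same carbon remains an open case, and so does whether a smaller atom such as fluorine would leave the number close to that of compound 1.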